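Swapping the dinitrophenyl of compound 3 for an aminophenyl

A few compounds are considered here, and "the series" means these few. Any claim that something is new, unique, unknown or untested is made for them only; others in the source may bear on it.

Measured so far:
Compound 1 `O=S(=O)(NCCNC(=S)Nc1ccc(Cl)cc1)c1ccc(-c2ccccc2OCc2ccccc2)s1` gives 7000 nM in a functional assay on HeLa cells (Homo sapiens) for inhibition, read by CCK-8 assay, with a stated time of 48 h; a lower number here means a stronger inhibitor, a higher number a weaker inhibitor.
Compound 2 `COc1ccc(NC(=S)NCCNS(=O)(=O)c2sccc2-c2ccc(C)cc2Oc2ccc(O)c(O)c2)cc1` reaches only a limit of the assay, > 20000 nM, in this assay.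
Compound 3 `O=C(NCCNS(=O)(=O)c1ccc(-c2ccccc2Oc2ccc([N+](=O)[O-])c([N+](=O)[O-])c2)s1)Nc1cc(C(F)(F)F)cc(C(F)(F)F)c1` also reaches only a limit, > 50000 nM, in this assay.

Compound 3 therefore has no number of its own; it sits at the limit of > 50000 nM in this assay, at which 1 of the 3 values shown sits, and one of the other two values is likewise a limit, (the limit of > 20000 nM in this assay, at which 1 of the 3 values shown sits). Compound 4 `Nc1ccc(Oc2ccccc2-c2ccc(S(=O)(=O)NCCNC(=O)Nc3cc(C(F)(F)F)cc(C(F)(F)F)c3)s2)cc1` keeps the rest of compound 3 and differs in one place: 4-aminophenyl in place of 3,4-dinitrophenyl on an oxygen on an aromatic ring. Within the data shown here, no pair of measured compounds differing in one place is known here, so no measured step guides the size of this change. Compound 4 is expected to stay weak, with an expected step of an at least 1.6-fold lower number from compound 3 to compound 4 (0.22 log units; that floor lies within the scatter). Compound 4 is estimated at 30000 nM, between 8000 nM and 100000 nM.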

Compound 4, half-maximal inhibitory concentration: > 20000 nM
Compound 4: a limit, no number (the forecaster's own chance of this, stated with the estimate: 50%); the middle value does not contradict the limit.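

Compound 3 and compound 4 both stop at a limit of the assay, so no step can be read between them. The compounds shown leave open whether 4-aminophenyl in place of 3,4-dinitrophenyl changes the result in this assay at all.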